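A few compounds are considered here, and "the series" means these few. Any claim that something is new, unique, unknown or untested is made for them only; others in the source may bear on it.

Compound 2 `COc1nn(-c2ccccn2)c2cc(-c3ccc([C@H]4C[C@@H]4C(=O)O)cc3)cc(F)c12` carries a methoxy group and a pyridin-2-yl group on its core. In a functional assay on cells for agonist activity at Free fatty acid receptor 1 (Mus musculus), read by FLIPR and calcium flux, with a stated time of 5 min (a lower number here means a smaller maximal response, a higher number a larger maximal response), compound 2 gives 19%, the highest of the three numbers measured, although compound 1 `Cc1ccc(-n2nc(C)c3c(F)cc(-c4ccc([C@H]5C[C@@H]5C(=O)O)cc4)cc32)cc1` gives 14%, which lies within the usual scatter of that value. Within the data shown here, compound 3 `COc1nn(-c2ccccn2)c2cc(-c3ccc([C@H]4C[C@@H]4C(=O)O)cc3)ccc12` gives 1%; the only single-site step measured, a number 18 percentage points lower from compound 2 to compound 3 (beyond the scatter), concerns hydrogen in place of fluoro and does not touch the change at hand. Compound 4 `COc1nn(-c2ccc(C)cc2)c2cc(-c3ccc([C@H]4C[C@@H]4C(=O)O)cc3)cc(F)c12` differs from compound 2 by 4-methylphenyl in place of pyridin-2-yl on an aromatic nitrogen. Among the measured compounds shown here, no measured step covers this exchange; compound 1 also bears a 4-methylphenyl group on an aromatic nitrogen and sits close to compound 2, so no step beyond the scatter is expected. Compound 4 is estimated at 16%, within 6% to 28%. That estimate means an expected a number 3 percentage points lower from compound 2 to compound 4 (within the scatter).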

Compound 4, largest response reached (reported as efficacy), in percent of the reference or control that the assay uses: 11%
Compound 4: middle estimate off by 5 percentage points, on the high side, and the stated range covers the measured number.
By their numbers in this assay, from the lowest: compounds 3, 4, 1 and 2 (each within the scatter of the next, the first and the last beyond it).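

In this assay, among these compounds, 4-methylphenyl in place of pyridin-2-yl on the aromatic nitrogen gives a number 8 percentage points lower from compound 2 to compound 4 (within the scatter) and is the first change tested at this position. Losing the ring nitrogen of pyridin-2-yl therefore produces no step beyond the scatter here. With 4-methylphenyl kept on that nitrogen, methoxy in place of methyl on the aromatic carbon gives a number 3 percentage points lower from compound 1 to compound 4 (within the scatter) and likewise stays inside the scatter. No supporting measurement is available to explain either result. On these data alone, whether a cyclohexyl group or a chain ending in an amine on that nitrogen would change the response remains open.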